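The source may hold more compounds than are shown below. What is called first, only, known or untested is meant among the compounds shown, and "the series" means these compounds.

Compound 3, with the structure `COc1ccc(-n2nc(C(=O)Nc3ccc(C(F)(F)F)cc3)nc2-c2cc(OC)c(OC)c(OC)c2)cc1`, gives 83% in a functional assay on the whole organism for inhibition, with Rattus norvegicus as the target, read by paw edema, with stated times of 30 min and 3 h, at a dose of 0.28 mmol/kg by the oral route; a higher number here means more inhibition at the dose given (going by the name of the read-out), a lower number less inhibition. Among the measured compounds shown here, it has the lowest of the three numbers measured so far: compound 1, `CNC(=O)c1nc(-c2cc(OC)c(OC)c(OC)c2)n(-c2ccc(OC)cc2)n1`, gives 95%, and compound 2, `COc1ccc(-n2nc(C(=O)Nc3cccc(F)c3)nc2-c2cc(OC)c(OC)c(OC)c2)cc1`, gives 92%. The step of a number 12 percentage points lower from compound 1 to compound 3 (beyond the scatter) is beyond the scatter, whereas a number 9 percentage points lower from compound 2 to compound 3 (within the scatter) is within it. Compound 4, `COc1ccc(-n2nc(C(=O)Nc3ccc(C(=O)O)cc3)nc2-c2cc(OC)c(OC)c(OC)c2)cc1`, is obtained by the change (carboxy in place of trifluoromethyl on an aromatic carbon). The measured steps all concern replacing the group on the amide-type nitrogen, and none swaps one substituent for another on an aromatic ring, so they bear on this change only loosely. The expected step from compound 3 is therefore no change at the digits printed from compound 3 to compound 4 (within the scatter), none beyond the scatter. For compound 4 the estimate is 83%, in the range 65% to 95%.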

Compound 4, a percentage reported as inhibition, in the whole organism at one dose (the size of the read-out at that dose, not a potency): 95%
Estimate against measurement, compound 4: 12 percentage points below; measured number inside the range.
By their numbers in this assay, from the lowest: compounds 3, 2, 1 and 4 (each within the scatter of the next, the first and the last beyond it).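

Among the compounds shown here, replacing trifluoromethyl with carboxy on this aromatic carbon gives the first measured step at this place in this assay (a number 12 percentage points higher from compound 3 to compound 4 (beyond the scatter)). With carboxy there, the amide shows no separation from the other two compounds (a number 3 percentage points higher from compound 2 to compound 4 (within the scatter); no change at the digits printed from compound 1 to compound 4 (within the scatter)), so the shortfall of 4-(trifluoromethyl)phenyl against methyl does not extend to 4-carboxyphenyl. Nothing here explains this step.

As far as these compounds go, whether an amine, a hydroxy group or a methyl ester at this place would read like carboxy remains open. So does the effect of carboxy elsewhere on this ring.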